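The source may hold more compounds than are shown below. What is called first, only, known or untested is meant among the compounds shown, and "the series" means these compounds.

Working notes on a set of four quinazoline-type compounds carrying a nitroimidazole on an alkoxy chain, tested in a functional assay on HT-29 cells (Homo sapiens) for cytotoxicity, read by sulforhodamine B assay, with a stated time of 72 h; on this read-out higher numbers stand for weaker inhibition and lower numbers for stronger inhibition.

Compound 1 `COc1cc2ncnc(Nc3ccc(F)c(Cl)c3)c2cc1OCCn1ccnc1[N+](=O)[O-]` reaches only a limit in this assay: its value, > 50000 nM, is a limit and not a number, and it sits at the limit of > 50000 nM in this assay, at which 1 of the 3 values shown sits. Compound 2 `COc1cc2ncnc(Nc3ccc(F)c(Cl)c3)c2cc1OCCCCn1ccnc1[N+](=O)[O-]` carries the chain extended by 2-(2-nitro-1H-imidazol-1-yl)ethyl in place of 2-nitro-1H-imidazol-1-yl on a saturated chain carbon, two bonds along the chain from an oxygen on an aromatic ring, and in this assay compound 2 gives 2210 nM, a step of an at least 22-fold lower number from compound 1 to compound 2 (1.35 log units; beyond the scatter). Compound 3 `C#Cc1cccc(Nc2ncnc3cc(OC)c(OCCCCn4ccnc4[N+](=O)[O-])cc23)c1` keeps the longer chain of compound 2 but bears 3-ethynylphenyl in place of 3-chloro-4-fluorophenyl on a nitrogen on an aromatic ring; in this assay compound 3 gives 10100 nM, a step of a 4.6-fold higher number from compound 2 to compound 3 (0.66 log units; beyond the scatter). The difference between the core of compound 1 and the core of compound 3 is not broken down here.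

Compound 4 `C#Cc1cccc(Nc2ncnc3cc(OC)c(OCCCCCCn4ccnc4[N+](=O)[O-])cc23)c1` is not yet measured. It differs from compound 3 by 2-(2-nitro-1H-imidazol-1-yl)ethyl in place of 2-nitro-1H-imidazol-1-yl on a saturated chain carbon, four bonds along the chain from an oxygen on an aromatic ring. This is the same kind of change as that from compound 1 to compound 2, but not the same: there the place was two bonds along the chain from an oxygen on an aromatic ring, here it is four bonds along the chain from an oxygen on an aromatic ring. The earlier step was large, yet it started from a shorter chain, so the second extension is expected to give a smaller gain: the estimated step for compound 4 is a 2.0-fold lower number from compound 3 to compound 4 (0.31 log units; beyond the scatter), resting on the direction of an at least 22-fold lower number from compound 1 to compound 2 (1.35 log units; beyond the scatter) and on the starting value of compound 3, 10100 nM. Compound 4 is expected to give about 5000 nM in this assay, plausibly between 1500 nM and 20000 nM.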

Compound 4, half-maximal inhibitory concentration: 2930 nM
Compound 4: the middle estimate sits 1.7-fold (0.23 log units) above what was measured; the measured number falls inside the stated range.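

In this assay the second chain extension again lowers the number, a 3.4-fold lower number from compound 3 to compound 4 (0.54 log units; beyond the scatter), so the direction of the change holds on both cores shown, but its size does not: the same change on two cores in this assay, an at least 22-fold lower number (1.35 log units; beyond the scatter) from compound 1 to compound 2 and a 3.4-fold lower number (0.54 log units; beyond the scatter) from compound 3 to compound 4, at least 6.5-fold (0.81 log units) apart, beyond the scatter of two such steps

The earlier step starts from a limit and not a number, as compound 1 gives > 50000 nM, so its size and the gap between the two steps are known only as bounds: the limit of > 50000 nM in this assay, at which 1 of the 4 values shown sits.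

The comparison does not show that the core alone sets the size of the step, since the two steps also start from different chain lengths, one with the change two bonds along the chain from the oxygen on the aromatic ring and the other four bonds along, and no pair shown makes the same extension from the same chain length on both cores.

Open, as far as these compounds go, is whether the number keeps falling with a chain longer than that of compound 4, and what the chain of compound 4 gives on the core of compound 2. Also open, from the compounds shown here alone, is how much of the cytotoxicity depends on the nitro group, which an unsubstituted imidazole or an amine at the end of the same chain would test in this assay.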